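A few compounds are considered here, and "the series" means these few. Any claim that something is new, unique, unknown or untested is made for them only; others in the source may bear on it.

Among the compounds with values here, in a functional assay on KB cells (Homo sapiens) for inhibition (on this read-out higher numbers stand for weaker inhibition and lower numbers for stronger inhibition), compound 2 `N#Cc1c(N)n(COCc2ccccc2)c2ncnc(N)c12` gives 118000 nM and compound 1 `NC(=S)c1c(N)n(COCc2ccccc2)c2ncnc(N)c12` gives 225000 nM, so compound 2 stands level with the only other number. Compound 3 `N#Cc1c(Br)n(COCc2ccccc2)c2ncnc(N)c12` reports only a limit, > 100000 nM. This leaves a step that the limit leaves unreadable from compound 2 to compound 3, and that step offers no guide. Compound 4 `NC(=O)c1c(N)n(COCc2ccccc2)c2ncnc(N)c12` carries carbamoyl in place of cyano on an aromatic carbon. Within the data shown here, the one readable step at that carbon, a 1.9-fold lower number from compound 1 to compound 2 (0.28 log units; within the scatter), also ends at cyano, and it stayed within the scatter. On that single step, no change beyond the scatter is expected, so the estimated outcome is a 1.4-fold higher number from compound 2 to compound 4 (0.16 log units; within the scatter). For compound 4 the expected value is 170000 nM, with an estimated range of 70000 nM to 400000 nM.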

Compound 4, half-maximal inhibitory concentration: > 100000 nM
Compound 4: no number, only a limit; the forecaster's own chance of this, stated with the estimate: 35%; the middle value is on the limit's open side.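

Compound 4 gives only a limit, > 100000 nM, so its steps from compound 1 and compound 2 cannot be read. The compounds shown leave open how compound 3 and compound 4 compare with compound 2, and one limit covers both: the limit of > 100000 nM in this assay, at which 2 of the 4 values shown sit.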